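The source may report more compounds than this note shows. Statements on the series, on what has been measured and on what is new or still open speak of the compounds shown alone.

Measured compounds:
- compound 1 `C=C(Br)C(=O)Nc1ccc2c(c1)/C(=C\c1cccs1)C(=O)N2`, which in a functional assay on MCF7 cells (Homo sapiens) for antiproliferative activity, read by MTT assay, with a stated time of 72 h (on this read-out higher numbers stand for weaker inhibition and lower numbers for stronger inhibition), gives 2300 nM
- compound 2 `C#CC(=O)Nc1ccc2c(c1)/C(=C/c1ccc[nH]1)C(=O)N2`, which in this assay gives 3700 nM
- compound 3 `C=C(Br)C(=O)Nc1ccc2c(c1)CC(=O)N2`, which in this assay gives 3300 nM

Among these three, compound 1 has the lowest number in this assay. Its nearest neighbour is compound 3, and the gap between the two lies within the usual scatter of this kind of measurement; the gap to compound 2 is the widest of the set and also lies within that scatter. Among the measured compounds shown here, none of the three can therefore be called more or less active than another on these numbers alone, and no pair of them differs in only one place, so no single structural step can be read off from what has been measured.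

The compound that follows, compound 4 `C=C(Br)C(=O)Nc1ccc2c(c1)/C(=C\c1sccc1C)C(=O)N2`, differs from compound 1 in one place: methyl in place of hydrogen on an aromatic carbon. Cut one bond further out, the change reads thiophen-2-yl to 3-methylthiophen-2-yl. For the measured compounds named here, the measured set gives no precedent for this kind of change, so any expectation must rest on the standing of compound 1 itself. The step from compound 1 to compound 4 is expected to be a 1.1-fold higher number from compound 1 to compound 4 (0.04 log units; within the scatter), that is, no movement beyond the scatter in either direction. Compound 4 is accordingly estimated at 2500 nM, with a range from 1000 nM to 6000 nM.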

Compound 4, half-maximal inhibitory concentration: 2300 nM
The estimate for compound 4 lay 1.1-fold (0.04 log units) above the measured number; low and high end bracket the measured number.
By their numbers in this assay, from the lowest: compounds 1, 4, 3 and 2 (each within the scatter of the next).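

In this assay, among the compounds shown here, the change from thiophen-2-yl to 3-methylthiophen-2-yl gives no change at the digits printed from compound 1 to compound 4 (within the scatter), the first comparison in the set that isolates a single place. For the compounds shown here, it shows that a methyl group can stand in place of hydrogen on this aromatic carbon, next to the ring atom that bears a large group and two ring bonds from the ring sulfur, with no movement in this read-out, something the earlier compounds could not show because no pair among them differed in only one place. No measurement at hand explains why the number stays where it is.

Methyl is the only replacement for hydrogen seen at this carbon, so it remains open whether an ethyl group, a methoxy group, an amine or a carboxylic acid would also leave the number unmoved. As far as these compounds go, it is also open whether methyl on the other carbons of the thiophene ring would read the same, or whether this step would hold on a compound with the alkyne amide of compound 2 in place of the bromoacrylamide.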